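The source may report more compounds than this note shows. Statements on the series, on what has been measured and on what is new or still open speak of the compounds shown alone.

Compound 1 `[N-]=[N+]=NCCCN1CCCC(COC(=O)c2ccccc2-c2ccccc2)C1` is the stronger of the two compounds measured in an in vitro functional assay on HEK ts201 cells for antagonist activity at Neuronal acetylcholine receptor; alpha3/beta4 (Homo sapiens), read by fluorescence and calcium flux (a lower number here means a stronger inhibitor, a higher number a weaker inhibitor), where compound 1 gives 1820 nM. Compound 2 `O=C(OCC1CCCNC1)c1ccccc1-c1ccccc1` shares the same core but carries hydrogen on the ring nitrogen, and in this assay compound 2 gives 8130 nM; the change from compound 1 to compound 2 is a 4.5-fold higher number from compound 1 to compound 2 (0.65 log units; beyond the scatter), so removing the whole chain from the ring nitrogen weakens inhibition.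

Compound 3 `COc1ccc(OCCCCCN2CCCC(COC(=O)c3ccccc3-c3ccccc3)C2)cc1` keeps the chain and alters its end: 2-(4-methoxyphenoxy)ethyl in place of azido on a saturated chain carbon, three bonds along the chain from an amine nitrogen in a ring. Going by the values given here, no measured step shows what a larger end on this chain does; the only step available, a 4.5-fold higher number from compound 1 to compound 2 (0.65 log units; beyond the scatter), shows that the chain itself matters. Extending it rather than removing it is therefore expected to leave the number near that of compound 1 or lower it modestly. Compound 3 is estimated at 900 nM, with a likely range of 200 nM to 4000 nM, which means an expected step of a 2.0-fold lower number from compound 1 to compound 3 (0.31 log units; beyond the scatter).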

Compound 3, half-maximal inhibitory concentration: 22400 nM
Compound 3: middle estimate off by 25-fold (1.40 log units), on the low side; measured number outside the range, above it.
By their numbers in this assay, from the lowest: compound 1; then compound 2; then compound 3.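

At this position the end of the chain matters, not only its presence: in this assay, the change at the chain end gives a 12-fold higher number from compound 1 to compound 3 (1.09 log units; beyond the scatter). Compound 2, which has hydrogen on the ring nitrogen and no chain at all, gives 8130 nM, and compound 3 gives 22400 nM, so a chain there does not strengthen inhibition in every case. Nothing available explains this loss of inhibition.

The compounds shown leave open whether the loss follows the greater length of the chain or the aromatic ring at its end. A plain, longer alkyl chain with no ring at its end, or an amine in place of the azido group, would help to separate these two possibilities.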